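The source may hold more compounds than are shown below. What is called first, only, known or untested is meant among the compounds shown, and "the series" means these compounds.

Measured compounds:
compound 1 `NC(=O)/C=C1\CCc2cc(Cl)ccc21` gives 29%
compound 2 `O=C(/C=C1\CCc2ccc(F)cc21)NCC1CC1` gives 21%

Both compounds were tested in a functional assay on the whole organism with Rattus norvegicus as the target, at a dose of 20 mg/kg by the oral route; on this read-out higher numbers stand for more inhibition at the one dose given (going by the name of the read-out) and lower numbers for less inhibition. On this read-out compound 2 gives 21%, and compound 1 gives 29%; the two numbers lie within the usual scatter of each other, so neither compound can be set apart from the other on these data.

Compound 3 `CON(C)C(=O)/C=C1\CCc2ccc(F)cc21` has not yet been measured. It differs from compound 2 in one place: methoxy(methyl)amino in place of (cyclopropylmethyl)amino on a carbonyl carbon. Going by the values given here, no measured pair with a single change of this kind is available, so the size of the step can only be guessed. Given that compound 2 gives 21%, the step is expected to stay within the scatter, with no clear direction; a change of a number 1 percentage points lower from compound 2 to compound 3 (within the scatter) is expected. Compound 3 is therefore estimated to give 20% in this assay, with a range from 5% to 38%.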

Compound 3, a percentage reported as inhibition, in the whole organism at one dose (the size of the read-out at that dose, not a potency): 14%
Compound 3: the middle estimate sits 6 percentage points above what was measured; the range from low to high includes it.
By their numbers in this assay, from the lowest: compounds 3, 2 and 1 (each within the scatter of the next, the first and the last beyond it).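

Going by these compounds alone, exchanging (cyclopropylmethyl)amino for methoxy(methyl)amino on a carbonyl carbon gives the first step that can be read in this assay: a number 7 percentage points lower from compound 2 to compound 3 (within the scatter). At this position, then, the read-out stays within the scatter when the three-membered ring and the hydrogen-bond donor of the leaving group are gone and the entering group brings a hydrogen-bond acceptor. Nothing available explains the size of this step.

From the compounds shown here alone, it remains open whether a carboxylic acid or a longer chain on the same carbonyl carbon would move the read-out beyond the scatter. Compound 1 differs from compound 2 and compound 3 in more than one place, so the part played by the substituents on the core cannot be read from these compounds.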